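A few compounds are considered here, and "the series" means these few. Any claim that something is new, unique, unknown or untested is made for them only; others in the source may bear on it.

Measured so far in a functional assay on MCF7 cells (Homo sapiens) for cytotoxicity, read by MTT assay, with a stated time of 48 h; on this read-out lower numbers stand for stronger inhibition and higher numbers for weaker inhibition:
compound 1, `Fc1ccc2nc(-c3ccccc3)nc(Nc3ccccc3)c2c1`, gives > 50000 nM.
compound 2, `Fc1cccc(-c2nc(Nc3ccc(Br)cc3)c3cc(F)ccc3n2)c1`, gives > 50000 nM.

The value for compound 1 is a limit of the assay, not a number. The value for compound 2 is likewise a limit. Among the measured compounds shown here, both entries rest at the limit of > 50000 nM in this assay, at which 2 of the 2 values shown sit, so compound 2 stands level with the only other entry, and no step between measured compounds can be sized; nothing shows how far beyond the limit either compound lies.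

Compound 3, `Cc1cccc(Nc2nc(-c3cccc(F)c3)nc3ccc(F)cc23)c1`, is the next entry for this assay. 3-methylphenyl in place of 4-bromophenyl on a nitrogen on an aromatic ring With both measured values being limits, no size can be read from the measured pair for this change; the expectation is of no movement beyond the scatter, with the reported value likely again a limit. Compound 3 is accordingly estimated at 60000 nM (range 20000 nM to 200000 nM), meaning an expected step that the limit leaves unreadable from compound 2 to compound 3.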

Compound 3, half-maximal inhibitory concentration: > 50000 nM
Compound 3: only a limit was reported (the forecaster's own chance of this, stated with the estimate: 85%); the middle value lies beyond the limit too.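

Compound 2 and compound 3 are both reported only as limits of the assay, so no step can be read for 3-methylphenyl in place of 4-bromophenyl: the limit of > 50000 nM in this assay, at which 3 of the 3 values shown sit.

The compounds shown leave open how far beyond the limit each lies and whether any change on the shared core gives a measurable value.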